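A Pyridinylmethylamino Analogue on the Shared Core

The source may hold more compounds than are shown below. What is called first, only, known or untested is meant among the compounds shown, and "the series" means these compounds.

Compound 1 `C[C@@H](NCC1CCN(CCCc2c[nH]c3ccc(-n4cnnc4)cc23)CC1)c1ccccc1` gives 1.4 nM in an assay on CHO cells for displacement of a labelled ligand from 5-hydroxytryptamine receptor 1D (Homo sapiens) (on this read-out lower numbers stand for stronger inhibition and higher numbers for weaker inhibition), the lowest of the three numbers in hand; compound 3 `c1ccc(NCC2CCN(CCCc3c[nH]c4ccc(-n5cnnc5)cc34)CC2)nc1` gives 1.7 nM and compound 2 `c1ccc(CNC2CCN(CCCc3c[nH]c4ccc(-n5cnnc5)cc34)CC2)cc1` gives 4.6 nM. Compound 4 `c1cncc(CNC2CCN(CCCc3c[nH]c4ccc(-n5cnnc5)cc34)CC2)c1` differs from compound 1 in one place: ((pyridin-3-yl)methyl)amino in place of ((1-phenylethyl)amino)methyl on a saturated ring carbon. Within the data shown here, the closest precedent is a 3.3-fold higher number from compound 1 to compound 2 (0.52 log units; beyond the scatter), where the same group left and benzylamino entered; compound 4 instead carries the six-membered aromatic ring with one hetero atom. The steps of a 1.2-fold higher number from compound 1 to compound 3 (0.08 log units; within the scatter) and a 2.7-fold lower number from compound 2 to compound 3 (0.43 log units; beyond the scatter) show that exchanging the carbon-only ring for one with a hetero atom moved the numbers only modestly. Compound 4 is therefore expected to land near compound 2, a modest rise from compound 1 of a 2.9-fold higher number from compound 1 to compound 4 (0.46 log units; beyond the scatter). Compound 4 is estimated at 4 nM, between 1.5 nM and 11 nM.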

Compound 4, half-maximal inhibitory concentration: 35 nM
Beside the measured number, compound 4's estimate is 8.8-fold (0.94 log units) below it; measured number above the stated range.
By their numbers in this assay, from the lowest: compounds 1 and 3 (each within the scatter of the next); then compound 2; then compound 4.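

In this assay, the exchange of phenyl for pyridin-3-yl gives a 7.6-fold higher number from compound 2 to compound 4 (0.88 log units; beyond the scatter), so a hetero atom in this aromatic ring is not tolerated equally in every side chain on this saturated ring carbon. The larger steps, a 25-fold higher number from compound 1 to compound 4 (1.40 log units; beyond the scatter) and a 21-fold higher number from compound 3 to compound 4 (1.31 log units; beyond the scatter), separate compound 4 from two side chains of the longer ((...)amino)methyl form, although compound 3 also carries a six-membered aromatic ring with 1 hetero atom. Nothing available explains this loss. Whether it is specific to pyridin-3-yl remains open, since the compounds shown do not include ((pyridin-4-yl)methyl)amino or ((pyridin-2-yl)methyl)amino at this position.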